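The compounds below may be only part of what the source reports. "The series", "measured", "known", "first", "only" and "open" are said of these compounds alone.

Within the data shown here, in an ADME assay on microsomes from liver (Homo sapiens) for metabolic stability, read by LC-MS, with a stated time of 10 min (on this read-out higher numbers stand for a more stable compound and lower numbers for a less stable compound), compound 3 (`C[C@@H]1CN(c2cccc3c2C[C@H](CN(C)[C@H]2CCCc4cccnc42)NC3)C[C@H](C)N1C`) gives 24.6%, the lowest of three numbers so far. Compound 2 (`CN(C[C@H]1Cc2c(cccc2N2CCN3CCC[C@H]3C2)CN1)[C@H]1CCCc2cccnc21`) gives 36.6%, and compound 1 (`CN(C[C@H]1Cc2c(cccc2N2CCN(C3COC3)CC2)CN1)[C@H]1CCCc2cccnc21`) gives 83.1%. Compound 4 (`CN(C[C@H]1Cc2c(cccc2N2C[C@H]3C[C@@H]2CN3)CN1)[C@H]1CCCc2cccnc21`) differs from compound 3 in one group: a group of 7 heavy atoms (5 carbon, 2 nitrogen; 2 five-membered non-aromatic rings with 1 hetero atom each) in place of a group of 9 heavy atoms (7 carbon, 2 nitrogen; one six-membered non-aromatic ring with 2 hetero atoms), on an aromatic carbon. Among the measured compounds shown here, three measured steps concern this same place: a number 46.5 percentage points lower from compound 1 to compound 2 (beyond the scatter) and a number 58.5 percentage points lower from compound 1 to compound 3 (beyond the scatter) are large, and a number 12 percentage points lower from compound 2 to compound 3 (beyond the scatter) is modest. For the measured compounds named here, no measured compound carries the entering group, so the size remains uncertain, but a moderate to large rise is expected, given that compound 3 already lies lowest at 24.6%. The expected change is a number 30.4 percentage points higher from compound 3 to compound 4 (beyond the scatter). For compound 4 the estimated value is 55%, with an estimated range of 30% to 80%.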

Compound 4, percent of the compound remaining: 100%
For compound 4 the middle estimate is 45 percentage points below the measured one; measured number outside the range, above it.
By their numbers in this assay, from the lowest: compound 3; then compound 2; then compound 1; then compound 4.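

In this assay, the bridged group with 2 five-membered non-aromatic rings, on this aromatic carbon, gives a number 75.4 percentage points higher from compound 3 to compound 4 (beyond the scatter) and a number 63.4 percentage points higher from compound 2 to compound 4 (beyond the scatter). It also passes the 4-(oxetan-3-yl)piperazin-1-yl compound, with a number 16.9 percentage points higher from compound 1 to compound 4 (beyond the scatter), so an oxetane is not needed for the highest number in this set. No evidence here bears on the reason for these steps. The entering group also differs by carrying 1 hydrogen-bond donor, and these compounds cannot separate that from the ring change. On these data alone, whether a methyl or acetyl group on that donor nitrogen retains this stability remains open.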